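Chloro for trifluoromethoxy: the step to compound 4

The compounds below may be only part of what the source reports. "The series", "measured", "known", "first", "only" and "open" are said of these compounds alone.

The series is read in an ADME assay on HepG2 cells (Homo sapiens) for cytotoxicity, read by luminescence, with a stated time of 72 h; a lower number here means that less compound is needed, a higher number that more compound is needed for the effect. Compound 1 (`CCOC(=O)c1c(-c2cccc(Cl)c2)[nH]c2cc(OC)ccc2c1=O`) gives > 21500 nM as a limit and not a number. Compound 2 (`CCOC(=O)c1c(-c2cccc(OC)c2)[nH]c2cc(C(F)(F)F)ccc2c1=O`) gives > 21500 nM as a limit as well. Compound 3 (`CCOC(=O)c1c(-c2cccc(OC(F)(F)F)c2)[nH]c2cc(C(F)(F)F)ccc2c1=O`) also gives > 21500 nM as a limit. Compound 3 thus has no numerical position, and neither of the other two compounds offers a number to compare it with. The whole picture so far is the limit of > 21500 nM in this assay, at which 3 of the 3 values shown sit, and nothing finer.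

Compound 4 (`CCOC(=O)c1c(-c2cccc(Cl)c2)[nH]c2cc(C(F)(F)F)ccc2c1=O`) carries chloro in place of trifluoromethoxy on an aromatic carbon, meta to a large group, as counted in chloro in place of trifluoromethoxy on an aromatic carbon here.

Among the compounds with values here, the one measured step at this substituent is a step that the two limits leave unreadable from compound 2 to compound 3 and it offers no size to carry over. The same chloro group is present in compound 1, which sits at the limit of > 21500 nM in this assay. No step beyond the scatter is therefore expected in either direction, and the estimated change is a step that the limit leaves unreadable from compound 3 to compound 4 at most in nominal terms. For compound 4 the estimate is 25000 nM within an expected range of 12000 nM to 45000 nM and a report as a limit is the likeliest outcome.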

Compound 4, half-maximal effective concentration: > 21500 nM
Compound 4 gave a limit, no number; the forecaster's own chance of this, stated with the estimate: 85%; the middle value is on the limit's open side.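

No new step can be read between compound 4 and compound 1, compound 2 or compound 3, as all four values are limits and not numbers. The series therefore rests on a single reading: the limit of > 21500 nM in this assay, at which 4 of the 4 values shown sit.

The compounds shown leave open whether any of these substituent changes on the shared core shifts the half-maximal effective concentration, and by how much.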